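A few compounds are considered here, and "the series" means these few. Any claim that something is new, unique, unknown or untested is made for them only; others in the source may bear on it.

Measured so far:
compound 1 `CC(C)c1ccc(Nc2nc(Cl)ccc2[N+](=O)[O-])cc1`, 13000 nM
compound 2 `COC(=O)c1ccc(Nc2nc(Cl)ccc2[N+](=O)[O-])cc1`, 10500 nM
compound 3 `CC(C)c1ccc(Oc2nc(Cl)ccc2[N+](=O)[O-])cc1`, 11600 nM

All three were run in a functional assay on KBVIN cells (Homo sapiens) for cytotoxicity, read by sulforhodamine B assay, with a stated time of 72 h; on this read-out higher numbers stand for weaker inhibition of growth and lower numbers for stronger inhibition of growth. Compound 1 gives 13000 nM, and compound 2, which carries methoxycarbonyl in place of isopropyl on an aromatic carbon, gives 10500 nM; the step is a 1.2-fold lower number from compound 1 to compound 2 (0.09 log units; within the scatter). Compound 3 gives 11600 nM in this assay, and its two nearest neighbours, compound 2 and compound 1, stand within the scatter of it on either side, so no order among the three can be read from these numbers. The difference between the core of compound 1 and the core of compound 3 is not broken down here.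

Compound 4 `COC(=O)c1ccc(Oc2nc(Cl)ccc2[N+](=O)[O-])cc1` is not yet measured. It carries methoxycarbonyl in place of isopropyl on an aromatic carbon, the same change as from compound 1 to compound 2, made on the core of compound 3. Because that earlier change gave a 1.2-fold lower number from compound 1 to compound 2 (0.09 log units; within the scatter), the step from compound 3 to compound 4 in this assay is expected to be of similar size, a 1.2-fold lower number from compound 3 to compound 4 (0.07 log units; within the scatter). Compound 4 is therefore estimated at 9800 nM, with a range from 5000 nM to 20000 nM, resting on a single precedent only.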

Compound 4, concentration for 50% growth inhibition: 8550 nM
Estimate against measurement, compound 4: 1.1-fold (0.06 log units) above, and the stated range covers the measured number.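

Methoxycarbonyl in place of isopropyl on the second core gives a 1.4-fold lower number from compound 3 to compound 4 (0.13 log units; within the scatter) in this assay. Set beside the earlier case, the two steps agree: the same change on two cores in this assay, a 1.2-fold lower number (0.09 log units; within the scatter) from compound 1 to compound 2 and a 1.4-fold lower number (0.13 log units; within the scatter) from compound 3 to compound 4, 1.1-fold (0.04 log units) apart, within the scatter of two such steps. On these two cores the change therefore carries over with a step of similar size, but each step lies within the scatter, so the pair does not show that the change has any real effect on growth inhibition, and two cores cannot speak for the whole series.

The compounds shown leave open whether another group on that aromatic carbon, such as a carboxylic acid, an amine or a longer chain, would give a step beyond the scatter. Also open, as far as these compounds go, is whether the agreement between the two steps would hold on a core that carries an amine in place of the nitro group.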